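A few compounds are considered here, and "the series" means these few. Any claim that something is new, unique, unknown or untested is made for them only; others in the source may bear on it.

Measured compounds:

- Compound 1, `Cn1cc(-c2cnc3[nH]cc(-c4ccccc4C#N)c3c2)cn1`, gives 11000 nM in a physicochemical assay for solubility, read by LC-MS, in phosphate buffer, measured as thermodynamic solubility, with a stated time of 24 h, at pH 7.4; on this read-out higher numbers stand for higher solubility and lower numbers for lower solubility.
- Compound 2, `Cn1cc(-c2cnc3[nH]cc(-c4ccccc4F)c3c2)cn1`, gives 14000 nM in this assay.
- Compound 3, `Cc1nn(C)cc1-c1cnc2[nH]cc(-c3cccc(C#N)c3)c2c1`, gives 2000 nM in this assay.

Compound 3 stands lowest of the three numbers; compound 1 is its nearest neighbour and compound 2 the furthest, and both gaps lie beyond the scatter. Going by the values given here, the only measured step, a 1.3-fold higher number from compound 1 to compound 2 (0.10 log units; within the scatter), swaps one small group for another and lies within the scatter.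

Compound 4, `N#Cc1cccc(-c2c[nH]c3ncc(N4CCNCC4)cc23)c1`, has not yet been measured. It differs from compound 3 in one place: piperazin-1-yl in place of 1,3-dimethyl-1H-pyrazol-4-yl on an aromatic carbon. Among the compounds with values here, no measured step bears on this change; the one step that is known concerns a different position and a different kind of group, so it gives no guide to the size or direction here. The estimate therefore rests on compound 3 alone and carries a wide range. Compound 4 is expected to give about 15000 nM in this assay, somewhere between 3000 nM and 80000 nM, which would mean an estimated step of a 7.5-fold higher number from compound 3 to compound 4 (0.88 log units; beyond the scatter).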

Compound 4, solubility: 240000 nM
Beside the measured number, compound 4's estimate is 16-fold (1.20 log units) below it; measured number outside the range, above it.
By their numbers in this assay, from the lowest: compound 3; then compounds 1 and 2 (each within the scatter of the next); then compound 4.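

Placing piperazin-1-yl on this aromatic carbon gives a 120-fold higher number from compound 3 to compound 4 (2.08 log units; beyond the scatter) in this assay, so this position can move the read-out by a large amount. The earlier measured step, a swap of small groups at a different place, showed no change beyond the scatter and gave no sign of this. The entering group differs from the leaving one in several counted ways at once, being a non-aromatic six-membered ring with a hydrogen-bond donor in place of an aromatic five-membered ring with none, and nothing shown here explains the size of the step.

The compounds shown leave open whether the step follows the ring's second nitrogen, the loss of the aromatic ring, or both. Morpholin-4-yl, with an oxygen in place of that nitrogen, or an open-chain amine on the same carbon would help separate these possibilities.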